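From compound 3 to compound 4: bromo for trifluoromethyl

A few compounds are considered here, and "the series" means these few. Any claim that something is new, unique, unknown or untested is made for them only; others in the source may bear on it.

Measured so far in an ADME assay on HepG2 cells (Homo sapiens) for cytotoxicity, read by luminescence, with a stated time of 72 h; on this read-out lower numbers stand for an effect already at smaller amounts and higher numbers for an effect only at larger amounts of compound
- Compound 1 `CCOC(=O)c1c(-c2cc(F)cc(OC)c2)[nH]c2cc(OC)ccc2c1=O` gives the limit > 21500 nM
- Compound 2 `CCOC(=O)c1c(-c2cccc(OC)c2)[nH]c2cc(OC)ccc2c1=O` gives the limit > 21500 nM
- Compound 3 `CCOC(=O)c1c(-c2cccc(C(F)(F)F)c2)[nH]c2cc(OC)ccc2c1=O` gives the limit > 21500 nM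

Compound 3 has no number in this assay and stands only at a limit of the assay. The whole set shares this position: the limit of > 21500 nM in this assay, at which 3 of the 3 values shown sit. Compound 4 `CCOC(=O)c1c(-c2cccc(Br)c2)[nH]c2cc(OC)ccc2c1=O` has not yet been measured. It differs from compound 3 as follows: bromo in place of trifluoromethyl on an aromatic carbon. The exchange takes place on an aromatic carbon and brings in bromo in place of trifluoromethyl.

Among the compounds with values here, two measured steps bear on it. Within the data shown here, the first is a step that the two limits leave unreadable from compound 1 to compound 2, and the second, which brought in the trifluoromethyl that now leaves, is a step that the two limits leave unreadable from compound 2 to compound 3. Neither has a readable size, so neither gives a direction for the new exchange. Each only ended at the same limit again. Compound 4 is therefore expected to stay at a limit too, as compound 3 does with > 21500 nM. The expected change is a step that the limit leaves unreadable from compound 3 to compound 4, and no step beyond the usual scatter is expected. For compound 4 the estimate is 30000 nM, with an expected range from 15000 nM to 60000 nM.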

Compound 4, half-maximal effective concentration: > 21500 nM
Compound 4: no number, only a limit (the forecaster's own chance of this, stated with the estimate: 85%); the middle value does not contradict the limit.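

Compound 4 also stands only at a limit in this assay, so its steps from compound 1, compound 2 and compound 3 cannot be read. The compounds shown leave open whether any exchange on this aromatic ring gives a readable effect, as the whole set shares one position: the limit of > 21500 nM in this assay, at which 4 of the 4 values shown sit.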